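A few compounds are considered here, and "the series" means these few. Any claim that something is new, unique, unknown or untested is made for them only; others in the source may bear on it.

In an assay on CHO cells for displacement of a labelled ligand from adenosine receptor A1 (Homo sapiens), read by scintillation counting, with a stated time of 120 min, tested at 10 uM (on this read-out lower numbers stand for less inhibition and higher numbers for more inhibition at the one concentration tested (going by the name of the read-out)), compound 2 `Nc1scc(CN2CCN(c3ccccc3F)CC2)c1C(=O)c1ccc(Cl)cc1` gives 4%, and compound 1 `Nc1scc(CN2CCN(c3ccc(F)cc3Cl)CC2)c1C(=O)c1ccc(Cl)cc1` gives 0%. Going by the values given here, compound 2 has the higher of the two numbers, yet the only measured step, a number 4 percentage points higher from compound 1 to compound 2 (within the scatter), lies within the scatter, so the two compounds cannot be told apart. Compound 3 `Nc1scc(CN2CCN(c3cccc(F)c3F)CC2)c1C(=O)c1ccc(Cl)cc1` differs from compound 2 by fluoro in place of hydrogen on an aromatic carbon. Among the compounds with values here, no measured step adds a fluoro to this ring, and the one step that does change this ring stayed within the scatter, so for compound 3 the expected step is no change at the digits printed from compound 2 to compound 3 (within the scatter). The estimate for compound 3 is 4%, expected between 0% and 15%.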

Compound 3, a percentage reported as inhibition, at one concentration (the size of the read-out at that concentration, not a potency): 0%
Compound 3: middle estimate off by 4 percentage points, on the high side; the range from low to high includes it.
By their numbers in this assay, from the lowest: compounds 1, 3 and 2 (each within the scatter of the next).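

Adding a fluoro on the aromatic carbon ortho to the fluoro group gives, in this assay, a number 4 percentage points lower from compound 2 to compound 3 (within the scatter), so this change shows no effect that can be told from the scatter. The swap of 2-chloro-4-fluorophenyl for 2,3-difluorophenyl gives no change at the digits printed from compound 1 to compound 3 (within the scatter), which means that the three halogen patterns on this ring cannot be told apart. No evidence bears on the reason for this result.

The compounds shown leave open whether a non-halogen group on this ring, such as an amine or a methoxy, would give a different reading. They also leave open whether replacing the 4-chlorophenyl on the carbonyl would change the reading.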